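Acetamide in place of the carboxylic acid of compound 1

The source may report more compounds than this note shows. Statements on the series, on what has been measured and on what is new or still open speak of the compounds shown alone.

Compound 1 `COc1cc2c(cc1O)CCC(C)(CC(=O)O)O2` is the carboxylic acid of a small series sharing one core. In an ADME assay on SH-SY5Y cells (Homo sapiens) for cytotoxicity, read by MTT assay, with a stated time of 24 h, tested at 50 uM (on this read-out lower numbers stand for a stronger effect and higher numbers for a weaker effect at the one concentration tested), compound 1 gives 61%, the lowest number among the three measured compounds; compound 3 stands nearest to it and compound 2 furthest. Compound 2 `COc1cc2c(cc1O)CCC(C)(CC(=O)N[C@@H](C)C(=O)O)O2` gives 100% and compound 3 `COc1cc2c(cc1O)CCC(C)(CCNC(=O)/C=C(C)/C=C/C=C(C)/C=C/C1=C(C)CCCC1(C)C)O2` gives 91.7%.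

Compound 4 `COc1cc2c(cc1O)CCC(C)(CCNC(C)=O)O2` has not yet been measured. It differs from compound 1 as follows: acetamidomethyl in place of carboxy on a saturated chain carbon bound to a saturated ring carbon.

Two observations bear on this step. First, the step of a number 39 percentage points higher from compound 1 to compound 2 (beyond the scatter) shows that converting the carboxylic acid of compound 1 into an amide while keeping a carboxy elsewhere lifted the number strongly. Second, compound 4 carries an amide on the chain and no carboxy at all, as does compound 3, which gives 91.7%, far from the number of compound 1. Both point the same way: removing the free carboxy of compound 1 is accompanied by weaker effect in this assay. Compound 4 is therefore expected to rise by a step of a number 29 percentage points higher from compound 1 to compound 4 (beyond the scatter), well beyond the scatter. The estimated value for compound 4 is 90%, with a range from 72% to 105%.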

Compound 4, a percentage reported as activity, at one concentration (the size of the read-out at that concentration, not a potency): 66.5%
For compound 4 the middle estimate is 23.5 percentage points above the measured one; the whole stated range lies above it.
By their numbers in this assay, from the lowest: compounds 1 and 4 (each within the scatter of the next); then compounds 3 and 2 (each within the scatter of the next).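

In this assay, acetamidomethyl in place of carboxy on a saturated chain carbon bound to a saturated ring carbon gives a number 5.5 percentage points higher from compound 1 to compound 4 (within the scatter) and so stays within the scatter, which shows that the free carboxy can leave this position without a clear change in the read-out. The presence or absence of a carboxy therefore does not by itself follow the numbers in these compounds, since the change that keeps a carboxy further out on the chain gives a number 39 percentage points higher from compound 1 to compound 2 (beyond the scatter) in the same test. An amide on the chain does not by itself bring a high number either: compound 4 gives 66.5% with its small acetyl group, whereas compound 3 gives 91.7% with its long unsaturated acyl group.

No measurement on hand explains why these numbers fall as they do. Still open, as far as these compounds go, is whether a primary amine or a methyl ester at this position would stay close to compound 1 or reach the higher numbers, and how acyl chains of intermediate length would read between the acetyl of compound 4 and the long acyl group of compound 3.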